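This account rests on a few compounds, and the source may have more. Where it says the series, first, only, none or still open, it means among the compounds named here.

Measured in a functional assay on MCF7 cells (Homo sapiens) for inhibition, read by sulforhodamine B assay; on this read-out lower numbers stand for stronger inhibition and higher numbers for weaker inhibition:
Compound 1 `O=C1C(N2CCCCC2)=CC(=O)c2c1nc1n2[C@H]2OC[C@@H](O)[C@H]2OC1`: > 8000 nM
Compound 2 `COc1ccccc1NC1=CC(=O)c2nc3n(c2C1=O)[C@H]1OC[C@@H](O)[C@H]1OC3`: > 4000 nM

Compound 2 has no number in this assay, only the limit > 4000 nM. Compound 1 likewise reads only as a limit, > 8000 nM. Within the data shown here, these two entries set no order and give no measured step.

Compound 3 `Cc1ccc(NC2=CC(=O)c3nc4n(c3C2=O)[C@H]2OC[C@@H](O)[C@H]2OC4)cc1` keeps the shared core of compound 2 and differs in one place: 4-methylphenyl in place of 2-methoxyphenyl on an amine nitrogen. No measured step sizes this change, so no shift beyond the usual scatter is expected in this assay, in either direction. The expected step that the limit leaves unreadable from compound 2 to compound 3 is small and rests only on the limit of compound 2, > 4000 nM. Compound 3 may well also be expected to return only a limit. If a number is obtained, compound 3 is estimated at 5000 nM, with an expected range of 1500 nM to 12000 nM.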

Compound 3, half-maximal inhibitory concentration: 1660 nM
The estimate for compound 3 lay 3.0-fold (0.48 log units) above the measured number; the measured number falls inside the stated range.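

In this assay, among these compounds, compound 3 is the first entry with a number rather than a limit, which shows that the aryl group on this amine nitrogen can change the read-out: 4-methylphenyl in place of 2-methoxyphenyl gives an at least 2.4-fold lower number from compound 2 to compound 3 (0.38 log units; beyond the scatter) in a single change. From the compounds shown here alone, the true size of this step stays unknown because compound 2 reads only as a limit: the limit of > 4000 nM in this assay, at which 1 of the 3 values shown sits. Compound 1 is also only a limit, > 8000 nM, and steps involving it cannot be read.

The change swaps the whole aryl group, so the shown compounds do not separate the loss of the methoxy group from the gain of the methyl group. Phenyl, 2-methylphenyl and 4-methoxyphenyl on the same amine nitrogen lie outside the set, so which feature carries the step remains open.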